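The compounds below may be only part of what the source reports. "The series", "measured", "known", "first", "only" and "open" are said of these compounds alone.

Working notes on the series. Three measured compounds share one core and differ only in the group on the amide-type nitrogen. Compound 1 `CCCNC(=O)c1cccc2nc(OCC)n(Cc3ccc(-c4ccccc4-c4nnn[nH]4)cc3)c12` gives 32.6% in an assay on isolated protein for inhibition of NEDD8-activating enzyme E1 regulatory subunit (Homo sapiens), read by Western blot, with stated times of 10 min and 30 min, tested at 25 uM; a lower number here means less inhibition, a higher number more inhibition at the concentration tested (going by the name of the read-out). Compound 2 `CCOc1nc2cccc(C(=O)NCCCN(C)C)c2n1Cc1ccc(-c2ccccc2-c2nnn[nH]2)cc1` gives 29.5%, and compound 3 `CCOc1nc2cccc(C(=O)NCCCOC)c2n1Cc1ccc(-c2ccccc2-c2nnn[nH]2)cc1` gives 27.9%. The number for compound 3 is the smallest of the three, but both of its steps are within the scatter: a number 4.7 percentage points lower from compound 1 to compound 3 (within the scatter) and a number 1.6 percentage points lower from compound 2 to compound 3 (within the scatter). Compound 4 `CCOc1nc2cccc(C(=O)Nc3ccccc3)c2n1Cc1ccc(-c2ccccc2-c2nnn[nH]2)cc1` is the next change at the same amide-type nitrogen: phenyl in place of 3-methoxypropyl on an amide-type nitrogen. Among the measured compounds shown here, the steps that bear on it, all at this nitrogen, were a number 3.1 percentage points lower from compound 1 to compound 2 (within the scatter), a number 4.7 percentage points lower from compound 1 to compound 3 (within the scatter) and a number 1.6 percentage points lower from compound 2 to compound 3 (within the scatter), none beyond the scatter. No step beyond the scatter is therefore expected in this assay, a number 2.1 percentage points higher from compound 3 to compound 4 (within the scatter). Compound 4 is estimated at 30%, within 15% to 45%.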

Compound 4, a percentage reported as inhibition, at one concentration (the size of the read-out at that concentration, not a potency): 34.6%
Compound 4: middle estimate off by 4.6 percentage points, on the low side; measured number inside the range.
By their numbers in this assay, from the lowest: compounds 3, 2, 1 and 4 (each within the scatter of the next).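

Phenyl on the amide-type nitrogen, with no chain and with a six-membered aromatic ring of carbon only, gives a number 6.7 percentage points higher from compound 3 to compound 4 (within the scatter) and a number 5.1 percentage points higher from compound 2 to compound 4 (within the scatter) and a number 2 percentage points higher from compound 1 to compound 4 (within the scatter) in this assay and so stays within the scatter of all three chain groups. The flat picture at this nitrogen therefore now covers an aromatic ring as well as open chains. Nothing at hand offers a reason for this flatness. Open, on these data alone, is whether a benzyl group, a substituted phenyl such as 4-methoxyphenyl, or a carboxylic acid at the end of a propyl chain would move the number beyond the scatter.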